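The source may report more compounds than this note shows. Statements on the series, on what has been measured and on what is new or still open speak of the compounds shown alone.

In a functional assay on MIA PaCa-2 cells (Homo sapiens) for inhibition, read by MTT assay, with a stated time of 72 h (a lower number here means a stronger inhibitor of growth, a higher number a weaker inhibitor of growth), compound 1, with the structure `O=S(=O)(NCCCCCCNCc1ccc(Br)cc1)c1ccc2c(c1)OCC2`, gives 13000 nM, the highest number among the three measured compounds. Compound 2, with the structure `O=S(=O)(NCCCNCC1COc2ccccc2O1)c1cc(C(F)(F)F)cc(C(F)(F)F)c1`, gives 2600 nM in this assay, and compound 3, with the structure `O=S(=O)(NCCCCCCNCc1ccc(Br)cc1)c1cc(C(F)(F)F)cc(C(F)(F)F)c1`, gives 2970 nM; both of these numbers lie well below that of compound 1. Compound 4, with the structure `O=S(=O)(NCCCCCCNCc1ccc(Br)cc1)c1c(Cl)cccc1Cl`, has not yet been measured. It differs from compound 1 in a single change on the sulfonyl sulfur: a group of 8 heavy atoms (6 carbon, 2 chlorine; one six-membered aromatic ring of carbon only) in place of a group of 9 heavy atoms (8 carbon, 1 oxygen; one five-membered non-aromatic ring with 1 hetero atom, one six-membered aromatic ring of carbon only), on a sulfonyl sulfur. Since the two measured compounds carrying a different aryl group on that sulfur both gave lower numbers, the expected step of a 2.2-fold lower number from compound 1 to compound 4 (0.34 log units; beyond the scatter) is downward and moderate, somewhat beyond the scatter. Compound 4 is therefore estimated at 6000 nM in this assay, within a range from 2500 nM to 15000 nM.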

Compound 4, concentration for 50% growth inhibition: 14700 nM
Compound 4: the middle estimate sits 2.5-fold (0.39 log units) below what was measured; measured number inside the range.
By their numbers in this assay, from the lowest: compounds 2 and 3 (each within the scatter of the next); then compounds 1 and 4 (each within the scatter of the next).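

In this assay, 2,6-dichlorophenyl on the sulfonyl sulfur gives a 1.1-fold higher number from compound 1 to compound 4 (0.05 log units; within the scatter), so the two compounds cannot be told apart. A new aryl group at this position therefore does not always bring the number down: with the rest of the structure shared, compound 3 gives 2970 nM, whereas compound 4 gives 14700 nM. Nothing measured here gives a reason for this difference. Going by these compounds, it remains open whether a phenyl ring carrying a single chlorine or a methoxy group on that sulfur would lie nearer compound 3 or compound 4.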